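Amide substituent change on a hydrazinyl urea series

This account rests on a few compounds, and the source may have more. Where it says the series, first, only, none or still open, it means among the compounds named here.

Measured compounds:
compound 1 `CCOC(=O)c1cc(C)cc(NNC(=O)Nc2cc(Cl)nc(Cl)c2)n1` – 760 nM
compound 2 `Cc1cc(NNC(=O)Nc2cc(Cl)nc(Cl)c2)nc(-c2ccc(F)cc2)c1` – 1300 nM
compound 3 `Cc1cc(NNC(=O)Nc2cc(Cl)nc(Cl)c2)nc(C(=O)N(C)C)c1` – > 19000 nM

All three share a core in which a hydrazinyl urea links a dichlorinated pyridine to a methylated pyridine, and they differ only in the group on that second ring. In a functional assay on CHO cells for antagonist activity at sphingosine 1-phosphate receptor 2 (Homo sapiens), read by fluorescence and calcium flux, with a stated time of 3 min (on this read-out lower numbers stand for stronger inhibition and higher numbers for weaker inhibition), compound 1 gives 760 nM. Compound 2 gives 1300 nM, a change of a 1.7-fold higher number from compound 1 to compound 2 (0.23 log units; within the scatter). For compound 3 the assay reports only a limit, > 19000 nM, so its true potency is not known beyond that bound (the limit of > 19000 nM in this assay, at which 1 of the 3 values shown sits). The steps of an at least 25-fold higher number from compound 1 to compound 3 (1.39 log units; beyond the scatter) and an at least 14-fold higher number from compound 2 to compound 3 (1.16 log units; beyond the scatter) are both large, but neither tests what happens on the amide nitrogen itself.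

Compound 4 `Cc1cc(NNC(=O)Nc2cc(Cl)nc(Cl)c2)nc(C(=O)N(C)C2CC2)c1` is compound 3 with cyclopropyl in place of methyl on an amide-type nitrogen. Within the data shown here, no measured pair changes this position, so the measured steps give no direction for it; both its neighbours sit at or beyond the limit. The expectation is therefore that compound 4 stays at a weak level, with a number no higher from compound 3 to compound 4 (the limit leaves the size open), and likely again reports only a limit. Compound 4 is estimated at 19000 nM, within 5000 nM to 60000 nM.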

Compound 4, half-maximal inhibitory concentration: > 20000 nM
Compound 4 ended at the assay's limit; the forecaster's own chance of this, stated with the estimate: 65%; middle value at least 1.0-fold (0.02 log units) away from the limit.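

In this assay compound 4 gives > 20000 nM, which is a limit and not a number, so replacing methyl with cyclopropyl on the amide-type nitrogen gives no measured potency. Among these compounds, the step from compound 3 to compound 4 cannot be read, since both ends are limits, the one for compound 4 being this: the limit of > 20000 nM in this assay, at which 1 of the 4 values shown sits. What the result does add is a second amide that stays far from the two compounds with measured values, with an at least 15-fold higher number from compound 2 to compound 4 (1.18 log units; beyond the scatter) and an at least 26-fold higher number from compound 1 to compound 4 (1.42 log units; beyond the scatter), so compound 3 and compound 4 both fall short of the ethoxycarbonyl of compound 1 and the 4-fluorophenyl of compound 2.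

As far as these compounds go, how weak compound 3 and compound 4 really are remains unknown, and so does whether cyclopropyl helps or harms at this nitrogen. Also open, from the compounds shown here alone, is whether an amide keeping its amide hydrogen, such as a methylcarbamoyl group, or a carboxylic acid on the same ring carbon would return to the range of compound 1 and compound 2.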